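Replacing the Cyclopropylphenyl Group of Compound 1

A few compounds are considered here, and "the series" means these few. Any claim that something is new, unique, unknown or untested is made for them only; others in the source may bear on it.

Measured compounds:
compound 1 `C[C@H](c1ccc(C(=O)NCCC(=O)O)cc1)N1C(=O)C(c2cccc(C3CC3)c2)=N[C@]12CC[C@@H](C(C)(C)C)CC2`: 1700 nM
compound 2 `CC(C)(C)CC[C@H](c1ccc(C(=O)NCc2nn[nH]n2)cc1)N1C(=O)C(c2ccc(F)cc2)=N[C@]12CC[C@@H](C(C)(C)C)CC2`: 90 nM
compound 3 `CC(C)(C)CC[C@H](c1ccc(C(=O)NCc2nn[nH]n2)cc1)N1C(=O)C(c2ccc(C(F)(F)F)cc2)=N[C@]12CC[C@@H](C(C)(C)C)CC2`: 190 nM

In an assay on membranes from liver for displacement of a labelled ligand from Glucagon receptor (Mus musculus), read by scintillation counting, with a stated time of 60 min (a higher number here means a weaker inhibitor, a lower number a stronger inhibitor), compound 1 gives 1700 nM, the highest of the three numbers. Compound 3 lies nearest with 190 nM, and compound 2 lies furthest with 90 nM. Compound 4 `C[C@H](c1ccc(C(=O)NCCC(=O)O)cc1)N1C(=O)C(c2cccc(Cl)c2F)=N[C@]12CC[C@@H](C(C)(C)C)CC2` differs from compound 1 in one place: 3-chloro-2-fluorophenyl in place of 3-cyclopropylphenyl on a carbon with a double bond to nitrogen.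

For the measured compounds named here, only one measured step is available, a 2.1-fold higher number from compound 2 to compound 3 (0.32 log units; beyond the scatter). It touches the same aryl group that is exchanged here, but in a pair carrying a different side chain, and it swaps one substituent rather than the whole ring, so it bears on the present change only loosely. Going by the values given here, no measured step covers the replacement of a cyclopropyl-bearing ring by a halogenated one. Given that the one aryl change on record was modest, and that compound 2, which carries a fluoro on that ring, shows the lowest number, a modest move toward a lower number is expected for compound 4, with the direction uncertain. Compound 4 is therefore estimated at 1000 nM, in the range 300 nM to 4000 nM. This estimate corresponds to an expected step of a 1.7-fold lower number from compound 1 to compound 4 (0.23 log units; within the scatter).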

Compound 4, half-maximal inhibitory concentration: 4000 nM
Compound 4: middle estimate off by 4.0-fold (0.60 log units), on the low side; measured number inside the range.
By their numbers in this assay, from the lowest: compound 2; then compound 3; then compound 1; then compound 4.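

In this assay, exchanging 3-cyclopropylphenyl for 3-chloro-2-fluorophenyl on the carbon with a double bond to nitrogen gives a 2.4-fold higher number from compound 1 to compound 4 (0.37 log units; beyond the scatter), so the whole ring at this position can be changed with only a modest effect while the side chain of compound 1 stays in place. This step also shows that a halogenated ring here does not by itself bring a lower number, which the earlier step on a different side chain, a 2.1-fold higher number from compound 2 to compound 3 (0.32 log units; beyond the scatter), could not show. No measurement at hand accounts for this rise.

From the compounds shown here alone, it remains open whether the chloro or the fluoro alone would give the same step, and how a methoxy group or a nitrile on that ring would read. Also open, going by these compounds, is whether this exchange would move the number the same way on the side chain of compound 2.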